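Shortening the oxime ether chain on a quinone core

The source may hold more compounds than are shown below. What is called first, only, known or untested is meant among the compounds shown, and "the series" means these compounds.

Compound 1, `CO/N=C/c1cc(OC)c2c(c1OC)C(=O)C=CC2=O`: in a functional assay on A549 cells (Homo sapiens) for antiproliferative activity (a lower number here means that less compound is needed, a higher number that more compound is needed for the effect), compound 1 gives > 10 ug/mL, which is a limit of the assay and not a number.
Compound 2, `COc1cc(/C=N/OCc2ccccc2)c(OC)c2c1C(=O)C=CC2=O`: in this assay compound 2 gives > 10 ug/mL, again a limit.
Compound 3, `CCCCCCCCCCCCO/N=C/c1cc(OC)c2c(c1OC)C(=O)C=CC2=O`: in this assay compound 3 gives > 10 ug/mL, also a limit.

Compound 3 therefore stands only at a limit, as do the other two values shown, so nothing separates the three. Among the measured compounds shown here, the one measured step, a step that the two limits leave unreadable from compound 1 to compound 2, is unreadable for the same reason. What the measurements do show is the limit of > 10 ug/mL in this assay, at which 3 of the 3 values shown sit.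

Compound 4, `CCCO/N=C/c1cc(OC)c2c(c1OC)C(=O)C=CC2=O`, differs from compound 3 by hydrogen in place of nonyl on a saturated chain carbon, three bonds along the chain from an oxygen on an unsaturated carbon. For the measured compounds named here, no measured step bears on this change, since the step from compound 1 to compound 2 cannot be read, and the chain lengths already tried all sit at the limit. The step is therefore expected to be a step that the limit leaves unreadable from compound 3 to compound 4, with nothing beyond the scatter foreseeable. For compound 4 the estimate is 15 ug/mL, in a range from 7 ug/mL to 40 ug/mL, with a limit rather than a number the most likely outcome.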

Compound 4, concentration for half-maximal effect: > 10 ug/mL
Compound 4: no number, only a limit (the forecaster's own chance of this, stated with the estimate: 75%); the middle value is on the limit's open side.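

Compound 4 also gives a limit of the assay rather than a number, so its steps from compound 1, compound 2 and compound 3 cannot be read: the limit of > 10 ug/mL in this assay, at which 4 of the 4 values shown sit. From the compounds shown here alone, whether any change to these oxime ether chains would bring a readable number in this assay stays open.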